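The source may report more compounds than this note shows. Statements on the series, on what has been measured and on what is new or still open speak of the compounds shown alone.

Two compounds carry numbers in an assay on COS-7 cells for inhibition of patatin-like phospholipase domain-containing protein 2 (Mus musculus), tested at 200 uM; on this read-out lower numbers stand for less inhibition and higher numbers for more inhibition at the one concentration tested (going by the name of the read-out). Compound 1 `CCOC(=O)c1cccc(-c2ccc(CN3CCCC3)cc2)c1` gives 33% in this assay. Compound 2 `CCOc1ccc(-c2cccc(S(=O)(=O)N(C)C)c2)cc1` gives 63% in this assay, the higher of the two numbers; its nearest neighbour is compound 1, whose number lies lower by a margin beyond the usual scatter. Within the data shown here, no two measured compounds differ in a single place, so no measured step exists to anchor a change at any position of the shared core. Compound 3 `CCOc1ccc(-c2cccc(C(=O)NC)c2)cc1` is not yet measured. It differs from compound 2 as follows: methylcarbamoyl in place of dimethylsulfamoyl on an aromatic carbon. Among the measured compounds shown here, with no measured step of this kind on record, the expected step in this assay is a moderate loss, a number 15 percentage points lower from compound 2 to compound 3 (beyond the scatter), though an outcome within the scatter cannot be ruled out. Compound 3 is estimated at 48%, with a range from 25% to 72%.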

Compound 3, a percentage reported as inhibition, at one concentration (the size of the read-out at that concentration, not a potency): 40%
The estimate for compound 3 lay 8 percentage points above the measured number; the measured number falls inside the stated range.
By their numbers in this assay, from the lowest: compounds 1 and 3 (each within the scatter of the next); then compound 2.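

In this assay, among these compounds, the change of dimethylsulfamoyl to methylcarbamoyl on an aromatic carbon gives the first measured step, a number 23 percentage points lower from compound 2 to compound 3 (beyond the scatter), showing that the group at this position affects the read-out at the one concentration tested. The entering group has 4 heavy atoms in place of 6 and 1 hydrogen-bond donor in place of 0, so size and donor count change together and this single step cannot separate them. Nothing on record accounts for the loss.

As far as these compounds go, it remains open whether dimethylcarbamoyl, which has no amide hydrogen, or methylsulfonyl at this aromatic carbon would stay closer to compound 2 or to compound 3. Also open, from the compounds shown here alone, is whether the same step would appear with a longer chain in place of the ethoxy group.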